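A butyl chain replaces hydrogen on the ring nitrogen

A few compounds are considered here, and "the series" means these few. Any claim that something is new, unique, unknown or untested is made for them only; others in the source may bear on it.

In a toxicity assay on THP-1 cells (Homo sapiens) for inhibition (on this read-out lower numbers stand for higher toxicity in this test and higher numbers for lower toxicity in this test), compound 3 `COc1ccc(-c2cnc(NC(=O)c3ccc(F)cc3)[nH]2)cc1` gives > 100000 nM, which is a limit and not a number. Compound 4 `CCCCn1c(-c2ccc(OC)cc2)cnc1NC(=O)c1ccc(F)cc1` carries butyl in place of hydrogen on an aromatic nitrogen. Compound 1 `CCCn1c(-c2ccc(OC)cc2)cnc1NC(=O)c1ccc(F)cc1`, with propyl on that nitrogen, gives > 100000 nM, also only a limit. Compound 2 `COc1ccc(-c2cnc(NC(=O)c3ccc(F)cc3)n2-c2ccccc2)cc1`, with phenyl there, gives 8800 nM. The phenyl group marks both large steps: an at least 11-fold lower number from compound 1 to compound 2 (1.05 log units; beyond the scatter) and an at least 11-fold higher number from compound 2 to compound 3 (1.05 log units; beyond the scatter). Butyl, like propyl, has no ring, so compound 1 is the closer guide, and its step stays unreadable: a step that the two limits leave unreadable from compound 1 to compound 3. A modest drop at most is expected, an at least 1.6-fold lower number from compound 3 to compound 4 (0.22 log units; that floor lies within the scatter), and another limit is quite possible. Compound 4 is estimated at 60000 nM, with an expected range of 20000 nM to 100000 nM.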

Compound 4, half-maximal cytotoxic concentration: > 100000 nM
Compound 4: no number, only a limit; the forecaster's own chance of this, stated with the estimate: 60%; at least 1.6-fold (0.22 log units) between middle value and limit.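

In this assay, the change from phenyl to butyl on the aromatic nitrogen gives an at least 11-fold higher number from compound 2 to compound 4 (1.05 log units; beyond the scatter). Going from propyl to butyl therefore brings no readable number, and among the groups shown on this nitrogen only phenyl gives one. The steps from compound 1 and from compound 3 to compound 4 cannot be read because both ends of each step are limits: the limit of > 100000 nM in this assay, at which 3 of the 4 values shown sit.

On these data alone, whether a longer chain such as hexyl, or a benzyl group, would give a readable number stays open. So does how far compound 1, compound 3 and compound 4 really differ from one another.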